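The source may report more compounds than this note shows. Statements on the series, on what has been measured and on what is new or still open speak of the compounds shown alone.

Measured compounds: compound 1, `COc1ccc(N2CCN(C(=S)SCc3ccc4nc(N)nc(N)c4c3)CC2)cc1`, gives 5960 nM; compound 2, `Nc1nc(N)c2cc(CSC(=S)N3CCN(c4ccc(F)cc4)CC3)ccc2n1`, gives 2110 nM.

Among the compounds with values here, compound 2 stands with the lowest of the two numbers in an assay on isolated protein for inhibition of Dihydrofolate reductase (Homo sapiens), read by spectrophotometry; a lower number here means a stronger inhibitor, a higher number a weaker inhibitor; its nearest neighbour is compound 1, whose number is higher, and the one measured step, a 2.8-fold lower number from compound 1 to compound 2 (0.45 log units; beyond the scatter), lies beyond the scatter. Compound 3, `Nc1nc(N)c2cc(CSC(=S)N3CCN(c4ccc([N+](=O)[O-])cc4)CC3)ccc2n1`, has not yet been measured in this assay. It differs from compound 2 by one change: nitro in place of fluoro on an aromatic carbon.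

Within the data shown here, only one measured step bears on this change, and it bears only loosely: it exchanged methoxy for fluoro at the same aromatic carbon, and it was modest, as a 2.8-fold lower number from compound 1 to compound 2 (0.45 log units; beyond the scatter) shows. Among the measured compounds shown here, nothing measured here tells how nitro behaves at that carbon, so there is no direct precedent for the step from fluoro to nitro. The account therefore expects a step in this assay of modest size at most, in either direction or none beyond the scatter, with a wide range to cover that uncertainty. On that basis compound 3 is estimated at 1600 nM, between 500 nM and 5000 nM, which would mean an expected step of a 1.3-fold lower number from compound 2 to compound 3 (0.12 log units; within the scatter).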

Compound 3, half-maximal inhibitory concentration: 1610 nM
Compound 3: the middle estimate sits 1.0-fold (0.00 log units) below what was measured; measured number inside the range.
By their numbers in this assay, from the lowest: compounds 3 and 2 (each within the scatter of the next); then compound 1.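

In this assay the exchange of 4-fluorophenyl for 4-nitrophenyl gives a 1.3-fold lower number from compound 2 to compound 3 (0.12 log units; within the scatter) and so cannot be told apart from no change, even though three heavy atoms with two hydrogen-bond acceptors replace a single fluorine. Methoxy now stands apart from both other groups at this aromatic carbon: the earlier compounds showed this for fluoro alone, and nitro gives a 3.7-fold lower number from compound 1 to compound 3 (0.57 log units; beyond the scatter) while remaining within the scatter of fluoro. No measurement shown accounts for either the similarity of the fluoro and nitro compounds or their gap from the methoxy compound.

The compounds shown leave open whether other groups at this carbon, such as an amine, a carboxylic acid, a nitrile or a longer chain, would also match fluoro and nitro or would instead fall with methoxy or move outside the range of all three. They also leave open whether the exchange of fluoro for nitro would read the same with any other change made elsewhere in the shared core.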